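The source may hold more compounds than are shown below. What is called first, only, known or untested is meant among the compounds shown, and "the series" means these compounds.

Measured so far:
compound 1 `O=C(Nc1ccc2nc(NC(=O)C3CCC3)sc2c1)c1c(Cl)cccc1Cl` – 0.013 ug/mL
compound 2 `CC(C)(C)OC(=O)Nc1nc2ccc(NC(=O)c3c(Cl)cccc3Cl)cc2s1` – 0.027 ug/mL

In a functional assay on WI-38 VA13 cells (Homo sapiens) for cytotoxicity (on this read-out lower numbers stand for an effect already at smaller amounts and higher numbers for an effect only at larger amounts of compound), compound 1 gives 0.013 ug/mL and compound 2 gives 0.027 ug/mL. Compound 2 thus has the higher of the two numbers, the step being a 2.1-fold higher number from compound 1 to compound 2 (0.32 log units; beyond the scatter).

Compound 3 `COc1cccc(Nc2nc3ccc(NC(=O)c4c(Cl)cccc4Cl)cc3s2)c1` has not been measured in this assay. It differs from compound 2 as follows: 3-methoxyphenyl in place of tert-butoxycarbonyl on a nitrogen on an aromatic ring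

For the measured compounds named here, only one measured step exists, a 2.1-fold higher number from compound 1 to compound 2 (0.32 log units; beyond the scatter), and it touches the same nitrogen on the aromatic ring, but there the carbonyl stayed and only the group on the carbonyl carbon was exchanged. Going by the values given here, the change from compound 2 to compound 3 removes the tert-butoxycarbonyl altogether and puts a 3-methoxyphenyl directly on that nitrogen; no measured pair shows such an exchange. Among the compounds with values here, the single step at this position was modest, so no large movement in this assay is expected in either direction, though the uncertainty is wider than for the measured step.

For compound 3 in this assay the estimate is 0.03 ug/mL, within 0.008 ug/mL to 0.12 ug/mL, which means an expected step of a 1.1-fold higher number from compound 2 to compound 3 (0.05 log units; within the scatter).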

Compound 3, half-maximal effective concentration: > 7.2 ug/mL
Compound 3 ended at the assay's limit (the forecaster's own chance of this, stated with the estimate: 5%); middle value at least 240-fold (2.38 log units) away from the limit.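

In this assay, the group on the nitrogen on an aromatic ring turns out to matter greatly, a point the earlier pair could not show: 3-methoxyphenyl in place of tert-butoxycarbonyl gives an at least 260-fold higher number from compound 2 to compound 3 (2.42 log units; beyond the scatter), and the same group in place of cyclobutylcarbonyl gives an at least 550-fold higher number from compound 1 to compound 3 (2.74 log units; beyond the scatter). Within these three compounds, the exchange on the carbonyl carbon gave only a 2.1-fold higher number from compound 1 to compound 2 (0.32 log units; beyond the scatter), so the large movement appears only where the carbonyl leaves and the aromatic ring enters. The value of compound 3 is a limit and not a number, so both new steps fix only a minimum size: the limit of > 7.2 ug/mL in this assay, at which 1 of the 3 values shown sits.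

The single change removes the carbonyl and brings in the aromatic ring together, so the compounds shown do not separate the contribution of each. A benzoyl group or an unsubstituted phenyl on this nitrogen, or the free amine, would help to separate them and would show whether the methoxy group of compound 3 plays any part.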